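The source may hold more compounds than are shown below. What is called first, only, known or untested is meant among the compounds shown, and "the series" means these compounds.

Measured so far:
- compound 1, `Cc1cc(-c2cnc(OCC34CCC(N)(CC3)CC4)c(C)c2)c2cnn(C)c2n1`: 2 nM
- compound 2, `Cn1nc(-c2ccc(OCC34CCC(O)(CC3)CC4)c(F)c2)c2cnc(N)nc21`: 75 nM
- compound 3, `Cc1cc(-c2ccnc3[nH]ncc23)cnc1OCC12CCC(N)(CC1)CC2`: < 1 nM

In an assay on THP-1 cells for antagonist activity at Toll-like receptor 8 (Homo sapiens) (a lower number here means a stronger inhibitor, a higher number a weaker inhibitor), compound 1 gives 2 nM. In this assay compound 3 gives < 1 nM, which is a limit of the assay rather than a number, as noted in the limit of < 1 nM in this assay, at which 1 of the 3 values shown sits. Compound 2, with 75 nM in this assay, stands highest of the two numbers available; compound 1 sits well below it, beyond the scatter.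

Compound 4, `Cn1nc(-c2ccc(OCC3CC4(CNC4)C3)c(F)c2)c2cnc(N)nc21`, is not yet measured. It differs from compound 2 by a group of 7 heavy atoms (6 carbon, 1 nitrogen; one four-membered non-aromatic ring of carbon only, one four-membered non-aromatic ring with 1 hetero atom) in place of a group of 9 heavy atoms (8 carbon, 1 oxygen; 2 six-membered non-aromatic rings of carbon only), on a saturated chain carbon bound to an oxygen on an aromatic ring. Among the measured compounds shown here, no pair of measured compounds differs in one place, so no measured step can be read directly. The only anchor is that compound 2 is the weakest number shown, leaving room downward. A step of modest size toward a lower number is expected, a 2.5-fold lower number from compound 2 to compound 4 (0.40 log units; beyond the scatter), though it may stay within the scatter. Compound 4 is expected to give 30 nM in this assay, within 8 nM to 150 nM.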

Compound 4, half-maximal inhibitory concentration: 10 nM
The estimate for compound 4 lay 3.0-fold (0.48 log units) above the measured number; the range from low to high includes it.
By their numbers in this assay, from the lowest: compound 1; then compound 4; then compound 2. At a limit, below all of these: compound 3.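

The first step readable in this assay at this place, on a saturated chain carbon bound to an oxygen on an aromatic ring, is a 7.5-fold lower number from compound 2 to compound 4 (0.88 log units; beyond the scatter) and it shows that the group there can be exchanged with the shared core held constant. The group with one four-membered non-aromatic ring of carbon only and one four-membered non-aromatic ring with 1 hetero atom gives the lower number, although it is the smaller group by heavy atoms. Both groups count 1 hydrogen-bond donor, 1 hydrogen-bond acceptor and no net charge, so the step arises without a change in those counts, and nothing measured here bears on its cause.

Open is whether the ring nitrogen itself matters, since only one group of this kind is shown. A carboxylic acid or an open-chain amine at this place would test how far the step extends.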